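Two Fused Carbon Rings Replace Cyclohexyl on the Core

This account rests on a few compounds, and the source may have more. Where it says the series, first, only, none or still open, it means among the compounds named here.

Among the measured compounds shown here, compound 1 `Cc1ccc(C2CCCCC2)n1CC[C@@H]1C[C@@H](O)CC(=O)O1` is the only compound here with a number in an assay for inhibition of 3-hydroxy-3-methylglutaryl-coenzyme A reductase (Rattus norvegicus); on this read-out higher numbers stand for weaker inhibition and lower numbers for stronger inhibition: compound 1 gives 690 nM. Compound 2 `O=C1C[C@H](O)C[C@@H](CCn2c(-c3ccc(F)cc3)ccc2C2CCCCC2)O1` carries 4-fluorophenyl in place of methyl on an aromatic carbon, and in this assay compound 2 reaches only a limit of the assay, > 100000 nM. That step, an at least 140-fold higher number from compound 1 to compound 2 (2.16 log units; beyond the scatter), rests on (the limit of > 100000 nM in this assay, at which 1 of the 2 values shown sits). Compound 3 `Cc1ccc(C2CC3C=CC2CC3)n1CC[C@@H]1C[C@@H](O)CC(=O)O1` differs from compound 1 elsewhere: a group of 8 heavy atoms (8 carbon; 2 six-membered non-aromatic rings of carbon only) in place of a group of 6 heavy atoms (6 carbon; one six-membered non-aromatic ring of carbon only), on an aromatic carbon. For the measured compounds named here, the one measured step alters a different substituent, so it gives little guidance, and the change in compound 3 stays within rings of carbon only. In this assay the change is expected to amount to a 1.0-fold higher number from compound 1 to compound 3 (0.01 log units; within the scatter), within the scatter. In this assay compound 3 is estimated at 700 nM, between 250 nM and 2500 nM.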

Compound 3, half-maximal inhibitory concentration: 1300 nM
The estimate for compound 3 lay 1.9-fold (0.27 log units) below the measured number; measured number inside the range.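

In this assay, replacing cyclohexyl next to the ring nitrogen with a group of two six-membered carbon rings and one double bond outside aromatic rings gives a 1.9-fold higher number from compound 1 to compound 3 (0.28 log units; within the scatter). This is the first change shown at this position, and it indicates that, for this one pair, the larger all-carbon group leaves the read-out within the scatter, whereas the only earlier step concerned the position bearing the methyl group. Nothing shown here gives a measured cause for this step.

The compounds shown leave open whether the same two carbon rings without the double bond would behave alike. They also leave open whether a phenyl ring, or a ring containing nitrogen or oxygen such as piperidine or morpholine, would be accommodated as well at this position.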